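The compounds below may be only part of what the source reports. "The series", "measured", "known", "first", "only" and "open" are said of these compounds alone.

Compound 1 `O=C(/C=C/CC1CCN(S(=O)(=O)c2ccccc2)CC1)NO` was put into a functional assay on HCT-116 cells (Homo sapiens) for inhibition, read by resazurin assay, with a stated time of 5 days (on this read-out lower numbers stand for stronger inhibition of growth and higher numbers for weaker inhibition of growth), where compound 1 is recorded as "not determined" (no result reported). Compound 2 `Cc1ccccc1S(=O)(=O)N1CCC(CCCC(=O)NO)CC1` was also put into this assay, and compound 2 is likewise recorded as "not determined" (no result reported), so compound 2 stands without any number. Among the compounds with values here, the only measured relative is compound 3 `O=C(CCCC1CCN(S(=O)(=O)c2ccc3ccccc3c2)CC1)NO`, which in this assay gives 1900 nM. Compound 4 `O=C(CCCC1CCN(S(=O)(=O)Nc2ccccc2)CC1)NO` has not yet been measured. It differs from compound 2 by one exchange on the sulfonyl sulfur: anilino in place of 2-methylphenyl on a sulfonyl sulfur. With no number for compound 2, the step to compound 4 cannot be sized from data, and compound 3 offers only a loose anchor, carrying a different ring on the same sulfur. A modestly weaker growth inhibition than compound 3 seems plausible for compound 4, not a shift far beyond the scatter. Compound 4 is therefore expected to give about 4000 nM, within a range from 1500 nM to 12000 nM.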

Compound 4, concentration for 50% growth inhibition: 2000 nM
For compound 4 the middle estimate is 2.0-fold (0.30 log units) above the measured one, within the range that was stated.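

In this assay, within the data shown here, compound 2 has no single number, so no step to compound 4 can be read. From the compounds shown here alone, what exchanging 2-methylphenyl for anilino does to growth inhibition stays open, and no evidence at hand bears on the result for compound 4.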